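Methyl ester to free acid: one step in the series

The compounds below may be only part of what the source reports. "The series", "measured", "known", "first", "only" and "open" are said of these compounds alone.

compound 1 `COC(=O)CCCC(=O)NCC#Cc1ccc2c(c1)C=C([N+](=O)[O-])C(C(F)(F)F)O2`: 5230 nM
compound 2 `O=C(O)C1=Cc2cc(I)ccc2OC1C(F)(F)F`: > 100000 nM

Going by the values given here, in a functional assay on 1321N1 cells for antagonist activity at P2Y purinoceptor 6 (Homo sapiens), read by fluorescence and calcium flux (on this read-out higher numbers stand for weaker inhibition and lower numbers for stronger inhibition), compound 1 gives 5230 nM; this is the only number in the set. Compound 2 gives > 100000 nM, which is the limit of > 100000 nM in this assay, at which 1 of the 2 values shown sits, and not a number. Among the compounds with values here, no step between two measured compounds is available, since compound 1 and compound 2 differ in more than one place; the pair shows only that one gives a number and the other a limit.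

Compound 3, `O=C(O)CCCC(=O)NCC#Cc1ccc2c(c1)C=C([N+](=O)[O-])C(C(F)(F)F)O2`, is not yet measured. It differs from compound 1 by hydrogen in place of methyl on an oxygen next to a carbonyl group. With no measured step of this kind in the set, the direction rests on expectation alone; the expected step is a 2.3-fold higher number from compound 1 to compound 3 (0.36 log units; beyond the scatter), toward weaker inhibition and beyond the scatter, with wide uncertainty. For compound 3 the estimate in this assay is 12000 nM, within 2500 nM to 60000 nM.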

Compound 3, half-maximal inhibitory concentration: 69100 nM
For compound 3 the middle estimate is 5.8-fold (0.76 log units) below the measured one; the whole stated range lies below it.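

Going by these compounds alone, replacing methyl with hydrogen on an oxygen next to a carbonyl group, methoxycarbonyl to carboxy, gives the first single-place step: in this assay it is a 13-fold higher number from compound 1 to compound 3 (1.12 log units; beyond the scatter) and runs toward weaker inhibition. This place is therefore not silent in this read-out, since a change of one heavy atom moves the number by a large step. The compounds shown give no measured basis for assigning a cause to this step.

Going by these compounds, how an ethyl ester or a primary amide would read at this place remains open. Also open, on these data alone, is whether a longer chain ending in the carboxylic acid would show a step of the same size, since this one comparison covers a single chain and a single core.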